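Compound 3: oxetan-3-yl exchanged for 3-(trifluoromethyl)phenyl

The source may hold more compounds than are shown below. What is called first, only, known or untested is meant among the compounds shown, and "the series" means these compounds.

In an ADME assay on microsomes from liver (Homo sapiens) for metabolic stability, read by LC-MS, with a stated time of 10 min (a higher number here means that more of the compound is left, a lower number that less of the compound is left), compound 1 (`CN(C[C@H]1Cc2c(cccc2N2CCN(C3COC3)CC2)CN1)[C@H]1CCCc2cccnc21`) gives 83.1% and compound 2 (`CCN(C[C@H]1Cc2c(cccc2N2CCNCC2)CN1)[C@H]1CCCc2cccnc21`) gives 79.1% so the two values lie within the scatter of each other. Compound 1 therefore stands level with compound 2 on the numbers available.

Compound 3 (`CN(C[C@H]1Cc2c(cccc2N2CCN(c3cccc(C(F)(F)F)c3)CC2)CN1)[C@H]1CCCc2cccnc21`) keeps the core of compound 1 but carries 3-(trifluoromethyl)phenyl in place of oxetan-3-yl on an amine nitrogen in a ring. Among the compounds with values here, no measured pair covers this change, and neither measured compound carries a six-membered aromatic ring of carbon only at this place, so the expectation remains uncertain.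

Starting from compound 1 at 83.1% a fall beyond the scatter is expected in this assay with the estimate being a number 21.1 percentage points lower from compound 1 to compound 3 (beyond the scatter) for this exchange. For compound 3 the estimated value is 62% with an expected range from 38% to 84% in this measurement.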

Compound 3, percent of the compound remaining: 90.3%
Compound 3: middle estimate off by 28.3 percentage points, on the low side, and the stated range ends below it.
By their numbers in this assay, from the lowest: compounds 2, 1 and 3 (each within the scatter of the next, the first and the last beyond it).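

On an amine nitrogen in a ring of the six-membered non-aromatic ring with 2 nitrogen, exchanging oxetan-3-yl for 3-(trifluoromethyl)phenyl in this assay gives a number 7.2 percentage points higher from compound 1 to compound 3 (within the scatter). Within the data shown here, this is the first reading with a six-membered aromatic ring of carbon only at this place, and it shows that a group of 10 heavy atoms in place of 4 leaves the value level with the oxetane. Nothing measured bears on why the two stand level.

Open, going by these compounds, is how an unsubstituted phenyl, a carboxylic acid or a longer alkyl chain on this nitrogen would read in this assay, and so whether the trifluoromethyl matters at all. Also open is which group, if any, at this place gives a value beyond the scatter of these compounds.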